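Trifluoromethyl for Methyl on the Sulfonyl of Compound 3

The source may report more compounds than this note shows. Statements on the series, on what has been measured and on what is new or still open speak of the compounds shown alone.

Compound 1, `CN(C)CC[C@H](CSc1ccccc1)Nc1ccc(S(=O)(=O)NC(=O)c2ccc(N3CCN(Cc4ccccc4-c4ccc(Cl)cc4)CC3)cc2)cc1`: in an assay on isolated protein for displacement of a labelled ligand from Apoptosis regulator Bcl-2 (Homo sapiens), read by fluorescence polarization (a lower number here means a stronger inhibitor, a higher number a weaker inhibitor), compound 1 gives < 1 nM, which is a limit of the assay rather than a number.
Compound 2, `Cc1cc(S(=O)(=O)NC(=O)c2ccc(N3CCN(Cc4ccccc4-c4ccc(Cl)cc4)CC3)cc2)ccc1N[C@H](CCN(C)C)CSc1ccccc1`: in this assay compound 2 gives < 1 nM, again a limit of the assay.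
Compound 3, `CN(C)CC[C@H](CSc1ccccc1)Nc1ccc(S(=O)(=O)NC(=O)c2ccc(N3CCN(Cc4ccccc4-c4ccc(Cl)cc4)CC3)cc2)cc1S(C)(=O)=O`: in this assay compound 3 gives < 1 nM, also a limit of the assay.

Compound 3 therefore stands where every measured compound stands: at the limit of < 1 nM in this assay, at which 3 of the 3 values shown sit. Because all three values sit at that limit, the three single-point steps among them cannot be read. The step that the two limits leave unreadable from compound 1 to compound 2, the step that the two limits leave unreadable from compound 1 to compound 3 and the step that the two limits leave unreadable from compound 2 to compound 3 are each unreadable in size, so none of them gives a direction to carry forward.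

The compound not yet measured is compound 4, `CN(C)CC[C@H](CSc1ccccc1)Nc1ccc(S(=O)(=O)NC(=O)c2ccc(N3CCN(Cc4ccccc4-c4ccc(Cl)cc4)CC3)cc2)cc1S(=O)(=O)C(F)(F)F`. The change from compound 3 is trifluoromethyl in place of methyl on a sulfonyl sulfur, on the sulfonyl sulfur attached to the aromatic carbon of the shared core.

For the measured compounds named here, no measured step bears on this change, and the measured steps themselves show nothing beyond the limit. The expectation for compound 4 is therefore that it, too, is reported at the limit, with an estimated step that the limit leaves unreadable from compound 3 to compound 4 that is not readable as a change. Compound 4 is estimated at 0.5 nM, with a range from 0.1 nM to 2 nM.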

Compound 4, inhibition constant: < 1 nM
Compound 4: only a limit was reported; the forecaster's own chance of this, stated with the estimate: 85%; the middle value does not contradict the limit.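

In this assay compound 4 gives < 1 nM, which is a limit of the assay and not a number. No step between compound 4 and compound 1, compound 2 or compound 3 can be read, because all four share one limit: the limit of < 1 nM in this assay, at which 4 of the 4 values shown sit.

The compounds shown leave open whether trifluoromethyl in place of methyl on the sulfonyl sulfur changes the true strength of inhibition at all.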